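Chromone amide series and its effect on liver cells

This account rests on a few compounds, and the source may have more. Where it says the series, first, only, none or still open, it means among the compounds named here.

Compound 1 `COc1ccc(CNC(=O)/C=C/c2coc3cc(OC)ccc3c2=O)cc1` was examined in a functional assay on L02 cells (Homo sapiens) for inhibition, read by MTT assay, with a stated time of 48 h; a lower number here means a stronger inhibitor, a higher number a weaker inhibitor. In this assay compound 1 gives > 200000 nM, which is a limit of the assay rather than a measured number. Two close relatives of compound 1 were measured in the same way. Compound 3 `COc1ccc(CNC(=O)/C=C/c2coc3cc(O)ccc3c2=O)cc1` carries hydrogen in place of methyl on an oxygen on an aromatic ring. In this assay compound 3 gives > 200000 nM, again a limit. Compound 2 `Cc1ccc(CNC(=O)/C=C/c2coc3cc(O)ccc3c2=O)cc1` carries methyl on an aromatic carbon where compound 3 carries methoxy. In this assay compound 2 gives > 200000 nM, also a limit. The two steps among these compounds, a step that the two limits leave unreadable from compound 1 to compound 3 and a step that the two limits leave unreadable from compound 2 to compound 3, cannot be sized, because the limit of > 200000 nM in this assay, at which 3 of the 3 values shown sit, leaves no number on either side to compare.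

Compound 4 `COc1ccc2c(=O)c(/C=C/C(=O)Nc3cccc(C)c3)coc2c1` has not yet been measured. It differs from compound 1 by 3-methylphenyl in place of 4-methoxybenzyl on an amide-type nitrogen. Among the measured compounds shown here, neither measured step touches the amide-type nitrogen, so no measured step bears on this change, and nothing here points to a move in either direction beyond the scatter. Compound 4 is therefore expected to sit at the same limit, with an estimated value of 300000 nM in a range from 100000 nM to 1000000 nM. The step that the limit leaves unreadable from compound 1 to compound 4 is thus expected to be unreadable in the same way.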

Compound 4, half-maximal inhibitory concentration: > 200000 nM
Compound 4: only a limit was reported (the forecaster's own chance of this, stated with the estimate: 85%); the middle value lies beyond the limit too.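

In this assay compound 4 gives > 200000 nM, which is a limit and not a measured number. The step from compound 1 to compound 4 cannot be sized, because no number stands on either side: the limit of > 200000 nM in this assay, at which 4 of the 4 values shown sit. The compounds shown leave open which change, if any, would bring a compound of this kind to a measurable value in this assay.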